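Compound 3 in the cytotoxicity series: notes

The source may report more compounds than this note shows. Statements on the series, on what has been measured and on what is new or still open speak of the compounds shown alone.

Compound 1 `CC(c1cc(=O)[nH]c(N(C)C)n1)c1c(F)cccc1F` gives 89000 nM
Compound 2 `Cc1c(C(C)c2c(F)cccc2F)nc(N(C)C)[nH]c1=O` gives > 17000 nM (a limit)
Compound 3 `Cc1c(C(C)c2ccccc2F)nc(N(C)C)[nH]c1=O` is not yet measured

In an ADME assay on MT4 cells (Homo sapiens) for cytotoxicity, read by MTT assay, with a stated time of 4 days (a higher number here means that more compound is tolerated, a lower number that less compound is tolerated), compound 2 gives only the limit > 17000 nM and no number. Among the compounds with values here, compound 1 at 89000 nM holds the only readable number. The change to compound 3 is hydrogen in place of fluoro on an aromatic carbon. Within the data shown here, the one measured step is a step that the limit leaves unreadable from compound 1 to compound 2 and it is a different change with no readable size. No step beyond the scatter is therefore expected, so the estimated step is a step that the limit leaves unreadable from compound 2 to compound 3 and no direction is favoured. For compound 3 the estimated value is 40000 nM (expected range 15000 nM to 100000 nM).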

Compound 3, half-maximal cytotoxic concentration: 44000 nM
Estimate against measurement, compound 3: 1.1-fold (0.04 log units) below; the measured number falls inside the stated range.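

In this assay no step can be read from compound 2 to compound 3, because compound 2 gives only a limit: the limit of > 17000 nM in this assay, at which 1 of the 3 values shown sits.

The compounds shown leave open the size and direction of the change from fluoro to hydrogen.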